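The compounds below may be only part of what the source reports. "The series", "measured", "known", "first", "only" and "open" are said of these compounds alone.

Working notes on the thiourea amide series.

Compound 1 `CSc1ccccc1NC(=S)N1CCc2c(sc(NC(=O)c3ccccc3Cl)c2C(N)=O)C1` and compound 2 `NC(=O)c1c(NC(=O)c2ccccc2Br)sc2c1CCN(C(=S)Nc1ccccc1Cl)C2` share one core and differ only in the aryl on the carbonyl carbon. In a functional assay on HeLa cells (Homo sapiens) for antiproliferative activity, with a stated time of 24 h (a lower number here means a stronger inhibitor, a higher number a weaker inhibitor), compound 1 gives 43600 nM. In this assay compound 2 gives 46900 nM. The two values lie within the scatter of each other, so no order between compound 1 and compound 2 can be read from them; both sit at a weak level in this assay.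

Compound 3 `NC(=O)c1c(NC(=O)c2cccc([N+](=O)[O-])c2)sc2c1CCN(C(=S)Nc1ccccc1Cl)C2` is the next member and has not yet been measured. It differs from compound 2 by 3-nitrophenyl in place of 2-bromophenyl on a carbonyl carbon. Going by the values given here, no measured pair shows this change, and the only two values in hand do not separate beyond the scatter, so there is no basis for a step of any direction. The expectation for compound 3 is therefore a step of a 1.0-fold lower number from compound 2 to compound 3 (0.02 log units; within the scatter) that stays within the scatter, with the new value near the level already seen. Compound 3 is estimated at 45000 nM, in a range from 15000 nM to 140000 nM.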

Compound 3, half-maximal inhibitory concentration: 40300 nM
The estimate for compound 3 lay 1.1-fold (0.05 log units) above the measured number; low and high end bracket the measured number.
By their numbers in this assay, from the lowest: compounds 3, 1 and 2 (each within the scatter of the next).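

In this assay the exchange of 2-bromophenyl for 3-nitrophenyl on a carbonyl carbon whose other neighbour is an amide-type nitrogen gives a 1.2-fold lower number from compound 2 to compound 3 (0.07 log units; within the scatter) and stays within the scatter. Going by these compounds alone, this is the first step that changes one place only, and it shows that this position tolerates the loss of the bromine and the entry of a nitro-bearing ring, with its two hydrogen-bond acceptors, without any separation between the two values, both of which remain at the weak level seen so far. No measurement in hand bears on this result, so nothing can be said about what lies behind it.

Whether any group at this carbonyl carbon can move the value beyond the scatter remains open, since the compounds shown carry only substituted phenyl rings there and include no ring bearing an amine or a carboxylic acid and no plain alkyl chain in place of the aryl. Also open is whether the level in this cell assay responds to changes elsewhere on the shared core, which no single-place step shown so far addresses.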